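The source may report more compounds than this note shows. Statements on the series, on what has been measured and on what is new or still open speak of the compounds shown alone.

Of the compounds shown here, three of one family have been measured in an assay for inhibition of ribonucleoside-diphosphate reductase RR1 (Homo sapiens), with a stated time of 30 min; on this read-out higher numbers stand for weaker inhibition and lower numbers for stronger inhibition. Compound 1 is `O=[N+]([O-])c1ccccc1NC(=S)N/N=C/c1ccc(O)cc1` and in this assay compound 1 gives 39300 nM. Compound 2 is `O=[N+]([O-])c1ccc(NC(=S)N/N=C/c2ccc(O)cc2)cc1`, built from the same atoms as compound 1 but joined differently; the difference between the two cores is not broken down here. In this assay compound 2 gives 45100 nM. Compound 3 is `Oc1ccc(/C=N/NC(=S)Nc2ccccc2O)cc1` and in this assay compound 3 gives 29300 nM. The three numbers all lie within the usual scatter of one another, so no ranking among them can be drawn.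

Compound 3 arises from compound 1 by one change, (hydroxy in place of nitro on an aromatic carbon). That change produced a 1.3-fold lower number from compound 1 to compound 3 (0.13 log units; within the scatter), a step that is within the scatter.

Compound 4, `Oc1ccc(/C=N/NC(=S)Nc2ccc(O)cc2)cc1`, has not yet been measured. It arises from compound 2 by the same kind of change, (hydroxy in place of nitro on an aromatic carbon), with the hydroxy now para to a large group where in compound 3 it is ortho to a large group. Since the measured example of this change, compound 1 to compound 3, gave a 1.3-fold lower number from compound 1 to compound 3 (0.13 log units; within the scatter), only a small step is expected from compound 2 to compound 4, estimated at a 1.3-fold lower number from compound 2 to compound 4 (0.11 log units; within the scatter). On that basis compound 4 is expected to give about 35000 nM in this assay, with a likely range from 15000 nM to 80000 nM.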

Compound 4, half-maximal inhibitory concentration: 43300 nM
For compound 4 the middle estimate is 1.2-fold (0.09 log units) below the measured one; the measured number falls inside the stated range.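

In this assay, putting hydroxy in place of nitro on the core of compound 2 gave a 1.0-fold lower number from compound 2 to compound 4 (0.02 log units; within the scatter), a step too small to count as a real change. Set beside the earlier example of the same swap, the two steps do not differ: the same change on two cores in this assay, a 1.3-fold lower number (0.13 log units; within the scatter) from compound 1 to compound 3 and a 1.0-fold lower number (0.02 log units; within the scatter) from compound 2 to compound 4, 1.3-fold (0.11 log units) apart, within the scatter of two such steps This shows that the swap left the number within the scatter on both cores, so the lack of a readable effect carried over from one core to the other; it does not show that a real effect was transferred, since neither step is large enough to give one, and two cores are too few to support a general rule for the series.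

What the compounds shown leave open is whether any other group in these places, such as an amine, a carboxylic acid or a methoxy group, could move the number beyond the scatter. They also leave open whether a change elsewhere on the shared core would shift the number, and whether hydroxy and nitro would still match once such a change was in place.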